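This account rests on a few compounds, and the source may have more. Where it says the series, first, only, none or still open, it means among the compounds named here.

In a functional assay on A-375 cells (Homo sapiens), read by thymidine incorporation (on this read-out higher numbers stand for weaker inhibition and lower numbers for stronger inhibition), compound 1, `C=CCCC(=O)N[C@H]1[C@@H](OCCCCCCCCCCCCCCCC)O[C@H](CO)[C@@H](O)[C@@H]1O`, gives only a limit of the assay, > 50 uM. Compound 3, `C=CCCC(=O)N[C@H]1[C@@H](OCCCCCCCCCCCCCCCC)O[C@H](CO)[C@@H](O)[C@@H]1OS(=O)(=O)O`, differs from it in one place: sulfo in place of hydrogen on an oxygen on a saturated carbon. In this assay compound 3 gives 7.2 uM, so the step is an at least 6.9-fold lower number from compound 1 to compound 3 (0.84 log units; beyond the scatter). Since it starts from a limit, its true size is not known exactly.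

Within the data shown here, compound 2, `CCCCCCCC/C=C\CCCCCCCCO[C@H]1O[C@H](CO)[C@@H](O)[C@H](O)[C@H]1NC(C)=O`, gives 4.8 uM in this assay; that number and the one for compound 3 lie within the scatter of each other, so no order between the two can be read. The difference between the core of compound 2 and the core of compound 1 is not broken down here.

Compound 4, `CCCCCCCC/C=C\CCCCCCCCO[C@H]1O[C@H](CO)[C@@H](O)[C@H](OS(=O)(=O)O)[C@H]1NC(C)=O`, has not yet been measured. It differs from compound 2 by sulfo in place of hydrogen on an oxygen on a saturated carbon, the same change as from compound 1 to compound 3, at the same kind of place. Among the measured compounds shown here, the only guide to its effect is the one measured case, where a limit was turned into a number, and it is not known whether the gain carries over to a core that already gives a measurable number. The step from compound 2 to compound 4 is expected to be a 3.2-fold lower number from compound 2 to compound 4 (0.51 log units; beyond the scatter), a smaller move than the one measured, resting on an at least 6.9-fold lower number from compound 1 to compound 3 (0.84 log units; beyond the scatter) and on its starting point being a limit. Compound 4 is therefore estimated to give about 1.5 uM in this assay, somewhere between 0.4 uM and 5 uM.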

Compound 4, concentration for 50% inhibition: 2.1 uM
Beside the measured number, compound 4's estimate is 1.4-fold (0.15 log units) below it; measured number inside the range.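

In this assay, sulfo in place of hydrogen on an oxygen on a saturated carbon again goes with a lower number, here with a 2.3-fold lower number from compound 2 to compound 4 (0.36 log units; beyond the scatter) as the new step, so on both cores the change points the same way. The size of the step does not carry over from one core to the other, and two cores alone cannot show whether even the direction would hold on a third: the same change on two cores in this assay, an at least 6.9-fold lower number (0.84 log units; beyond the scatter) from compound 1 to compound 3 and a 2.3-fold lower number (0.36 log units; beyond the scatter) from compound 2 to compound 4, at least 3.0-fold (0.48 log units) apart, beyond the scatter of two such steps. From the compounds shown here alone, compound 1 stands at a limit of the assay and not at a number, so the step that starts from it has no exact size and the true gap between the two steps stays unknown: the limit of > 50 uM in this assay, at which 1 of the 4 values shown sits.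

The compounds shown leave open whether the same change would act alike on a core with a longer or shorter chain on the oxygen, and whether a carboxylic acid or a phosphate in place of sulfo would move the number in the same way. They also do not separate which of the several differences between the core of compound 1 and the core of compound 2 goes with the smaller step.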